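A few compounds are considered here, and "the series" means these few. Any claim that something is new, unique, unknown or untested is made for them only; others in the source may bear on it.

Working notes on the series. In an ADME assay on HEK293 cells (Homo sapiens) for cytotoxicity, read by MTT assay, with a stated time of 48 h (a higher number here means a weaker inhibitor, a lower number a stronger inhibitor), compound 1 `CC1(C)CCCC2=CC=C(C=O)CC[C@]21C` gives 696000 nM. Compound 3 `C=C1CCC[C@]2(C)CCC(c3cn(CC(=O)Nc4ccc(C)cc4)nn3)=CC[C@@]12C` gives 622000 nM in this assay. Compound 2 `C=C1CCC[C@]2(C)CCC(c3cn(-c4ccc(I)cc4)nn3)=CC[C@@]12C` has the lowest number of the three at 215000 nM, and its gaps to compound 3 and to compound 1 both lie beyond the scatter. Going by the values given here, all three numbers are high, and no measured pair differs in one place only.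

The next compound is compound 4 `C=C1CCC[C@]2(C)CCC(c3cn(-c4ccc(Cl)cc4)nn3)=CC[C@@]12C`, which differs from compound 2 at a single site: chloro in place of iodo on an aromatic carbon. In words, this is chloro in place of iodo on an aromatic carbon, para to a large group, or 4-iodophenyl to 4-chlorophenyl. Among the compounds with values here, the series holds no measured halogen exchange, so the expectation has no direct precedent. It rests on the small size of the change and on the narrow span of the measured numbers, with compound 2 at 215000 nM as the starting point.

In this assay, the expected result is a step within the scatter, leaning slightly toward a higher number, estimated as a 1.3-fold higher number from compound 2 to compound 4 (0.11 log units; within the scatter). For compound 4 the estimated value is 280000 nM, with an expected range from 140000 nM to 600000 nM.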

Compound 4, half-maximal inhibitory concentration: 609000 nM
For compound 4 the middle estimate is 2.2-fold (0.34 log units) below the measured one; the whole stated range lies below it.
By their numbers in this assay, from the lowest: compound 2; then compounds 4, 3 and 1 (each within the scatter of the next).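

Going by these compounds alone, the exchange of iodo for chloro on an aromatic carbon, para to a large group, is the first comparison that differs in one place only, and in this assay it gives a 2.8-fold higher number from compound 2 to compound 4 (0.45 log units; beyond the scatter). This position therefore responds to which halogen it carries: one heavy atom is exchanged for one heavy atom, with no ring, hydrogen-bond donor, hydrogen-bond acceptor or net charge entering or leaving, and the step still lies beyond the scatter. The low number of compound 2 thus depends on the iodo group and is not shared by the chloro compound, but no supporting measurement bears on why this halogen exchange moves the number.

From the compounds shown here alone, what a bromo, a fluoro or an amine would give at this position stays open, and so does whether the numbers would change gradually across the halogens or iodo alone would stand apart. This single pair also leaves open whether the same exchange would give a step of similar size on another aryl group attached to the shared core.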